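Step from compound 3 to compound 4 in a benzothiazole series

A few compounds are considered here, and "the series" means these few. Any claim that something is new, unique, unknown or untested is made for them only; others in the source may bear on it.

Compound 1, `COc1cc(N(Cc2ccccc2)C(=O)CSc2nc3ccccc3s2)cc(OC)c1OC`, gives 54500 nM in a functional assay on HCT-116 cells (Homo sapiens) for antiproliferative activity, read by MTT assay, with a stated time of 48 h; on this read-out higher numbers stand for weaker inhibition and lower numbers for stronger inhibition.
Compound 2, `COc1ccc(CN(C(=O)CSc2nc3ccccc3s2)c2cc(OC)c(OC)c(OC)c2)cc1O`, gives 182 nM in this assay.
Compound 3, `COc1ccc(CN(C(=O)CSc2nc3ccccc3s2)c2cc(OC)c(OC)c(OC)c2)cc1C(F)(F)F`, gives > 80000 nM in this assay.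

Compound 3 stands at the limit of > 80000 nM in this assay, at which 1 of the 3 values shown sits, so its result is a limit of the assay rather than a number. Compound 4 is `COc1cc(N(Cc2ccc(Cl)cc2)C(=O)CSc2nc3ccccc3s2)cc(OC)c1OC` and has not yet been measured. The change is 4-chlorophenyl in place of 4-methoxy-3-(trifluoromethyl)phenyl on a saturated chain carbon bound to an amide-type nitrogen.

Among the compounds with values here, two measured steps bear on the ring placed here. The step of a 300-fold lower number from compound 1 to compound 2 (2.48 log units; beyond the scatter) shows that a ring carrying hydroxy and methoxy groups brings a large drop in the number, while an at least 430-fold higher number from compound 2 to compound 3 (2.64 log units; beyond the scatter) shows that swapping that hydroxy for trifluoromethyl undoes the gain completely. The step of an at least 1.4-fold higher number from compound 1 to compound 3 (0.16 log units; that floor lies within the scatter) lies within the scatter, so a ring without hydroxy looks much like plain phenyl. Compound 4 carries a 4-chlorophenyl ring with no hydroxy and no acceptor, so its number is expected to sit near that of compound 1 rather than compound 2. The step of an at least 1.6-fold lower number from compound 3 to compound 4 (0.20 log units; that floor lies within the scatter) is therefore expected to be small, and compound 4 is estimated at 50000 nM, with a range from 12000 nM to 200000 nM.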

Compound 4, half-maximal inhibitory concentration: 603000 nM
Compound 4: middle estimate off by 12-fold (1.08 log units), on the low side, and the stated range ends below it.
By their numbers in this assay, from the lowest: compound 2; then compound 1; then compound 4.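

Chloro in place of hydrogen on an aromatic carbon brings an 11-fold higher number from compound 1 to compound 4 (1.04 log units; beyond the scatter), so at this position in this assay a ring without hydroxy need not sit level with plain phenyl, and a single added atom can move the number well past it. Set against the 3-hydroxy-4-methoxyphenyl ring, 4-chlorophenyl gives a 3300-fold higher number from compound 2 to compound 4 (3.52 log units; beyond the scatter), which shows in a fully readable pair how far the number at this position depends on the ring placed there. The step from compound 3 to compound 4 cannot be read, and the result for compound 3 is a limit of the assay: the limit of > 80000 nM in this assay, at which 1 of the 4 values shown sits.

The compounds shown leave open whether the hydroxy alone accounts for the low number of compound 2 or whether it needs the methoxy on the same ring, and whether an amine or a carboxylic acid in place of that hydroxy would hold the number down. From the compounds shown here alone, it also remains open whether the rise with chloro is particular to that atom or would recur with fluoro, bromo or methyl in its place.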